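This account rests on a few compounds, and the source may have more. Where it says the series, first, only, none or still open, it means among the compounds named here.

Compound 1 `COc1ccc(C2=C(c3ccc(SC)cc3)CC3CCCN3C2=O)cc1O`: 5000 nM
Compound 2 `CSc1ccc(C2=C(c3ccc(OCC4CO4)cc3)C(=O)N3CCCC3C2)cc1`: 80 nM
Compound 3 `CSc1ccc(C2=C(c3ccc(F)cc3)C(=O)N3CCCC3C2)cc1`: 90 nM

All three values come from a functional assay on U-251 cells (Homo sapiens) for cytotoxicity; on this read-out higher numbers stand for weaker inhibition of growth and lower numbers for stronger inhibition of growth. Compound 3 has one close neighbour and one distant one on this scale. There is a 1.1-fold higher number from compound 2 to compound 3 (0.05 log units; within the scatter), and there is a 56-fold lower number from compound 1 to compound 3 (1.74 log units; beyond the scatter).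

The next compound, compound 4 `CSc1ccc(C2=C(c3ccc(SC)cc3)C(=O)N3CCCC3C2)cc1`, has not yet been measured. It keeps the rest of compound 3 and differs in one group, with methylsulfanyl in place of fluoro on an aromatic carbon, para to a large group (methylsulfanyl in place of fluoro on an aromatic carbon). The same difference can be read as 4-fluorophenyl to 4-(methylsulfanyl)phenyl.

Both measured steps change this same aromatic ring. The closer guide is the swap of one group on it, which stayed within the scatter at a 1.1-fold higher number from compound 2 to compound 3 (0.05 log units; within the scatter). The step from compound 1 replaced a differently substituted ring and was large, so the range is kept wide.

In this assay the expected step is a 1.1-fold higher number from compound 3 to compound 4 (0.05 log units; within the scatter), which would be no change beyond the scatter. For compound 4 the estimated value is 100 nM, with an expected range from 30 nM to 350 nM.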

Compound 4, concentration for 50% growth inhibition: 5000 nM
Compound 4: the middle estimate sits 50-fold (1.70 log units) below what was measured, outside the stated range (above it).
By their numbers in this assay, from the lowest: compounds 2 and 3 (each within the scatter of the next); then compounds 1 and 4 (each within the scatter of the next).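

In this assay, the aromatic carbon para to a large group proves sensitive to which group sits there: fluoro and (oxiran-2-yl)methoxy gave numbers within the scatter of each other, but methylsulfanyl gives a 56-fold higher number from compound 3 to compound 4 (1.74 log units; beyond the scatter) and a 63-fold higher number from compound 2 to compound 4 (1.80 log units; beyond the scatter). A change of only two heavy atoms in for one out is therefore enough for a large step, and the earlier flat step did not reveal this. Placing 4-(methylsulfanyl)phenyl in place of 3-hydroxy-4-methoxyphenyl on the double-bonded ring carbon gives no change at the digits printed from compound 1 to compound 4 (within the scatter), so this swap on the other ring leaves the number where it was.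

No measurement at hand explains the jump at this position. On these data alone, it remains open how an amine, a chloro group or a longer chain such as ethylsulfanyl would behave on this aromatic carbon.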